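Acetylthiophene in place of dimethylaminophenyl on an amide scaffold

The compounds below may be only part of what the source reports. "The series", "measured", "known", "first", "only" and "open" are said of these compounds alone.

Compound 1, `CC(C)N(Cc1cccc(OCCCCCC(=O)O)c1)C(=O)c1ccc(-c2cccc(N(C)C)c2)cc1`, reaches only the limit > 26000 nM in an ADME assay on Raji cells (Homo sapiens) for cytotoxicity, read by CellTiter-Glo and resazurin assay, with a stated time of 72 h; a lower number here means that less compound is needed, a higher number that more compound is needed for the effect.
Compound 2, `CC(C)N(Cc1cccc(OCCCCCC(=O)O)c1)C(=O)c1ccc(-c2ccc(Cl)c(Cl)c2)cc1`, likewise gives only the limit > 26000 nM in this assay.
Compound 3, `CCOC(=O)CCCCCOc1cccc(CN(C(=O)c2ccc(-c3cccc(N(C)C)c3)cc2)C(C)C)c1`, also stops at the limit > 26000 nM in this assay.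

Compound 3 therefore stands where all three measured compounds stand: at the assay limit, with no number to place it above or below its neighbours (the limit of > 26000 nM in this assay, at which 3 of the 3 values shown sit). The two measured steps, a step that the two limits leave unreadable from compound 1 to compound 2 and a step that the two limits leave unreadable from compound 1 to compound 3, are both hidden between limits and give no readable size in either direction.

Compound 4, `CCOC(=O)CCCCCOc1cccc(CN(C(=O)c2ccc(-c3ccc(C(C)=O)s3)cc2)C(C)C)c1`, is not yet measured in this assay. It differs from compound 3 by 5-acetylthiophen-2-yl in place of 3-(dimethylamino)phenyl on an aromatic carbon. Neither measured step touches this change; both concern the other end of the shared core or its acid, and both are unreadable. With every comparator at the limit, the account expects compound 4 to remain there too, with an expected step that the limit leaves unreadable from compound 3 to compound 4, meaning no movement beyond the scatter.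

The estimate for compound 4 in this assay is 30000 nM, expected to fall between 12000 nM and 90000 nM, most likely reported as a limit again.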

Compound 4, half-maximal effective concentration: > 26000 nM
Compound 4: no number, only a limit; the forecaster's own chance of this, stated with the estimate: 80%; the middle value does not contradict the limit.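

In this assay compound 4 gives only a limit, > 26000 nM, so with compound 3 also at a limit, the step between compound 3 and compound 4 cannot be read. The compounds shown leave open whether any of these changes moves the half-maximal effective concentration, as all share one position: the limit of > 26000 nM in this assay, at which 4 of the 4 values shown sit.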